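Replacing hydroxy with fluoro on the shared core

The source may report more compounds than this note shows. Statements on the series, on what has been measured and on what is new or still open speak of the compounds shown alone.

Measured in a functional assay on Ehrlich cells (Mus musculus) for inhibition; on this read-out lower numbers stand for stronger inhibition and higher numbers for weaker inhibition:
- compound 1 `O=C(O)c1cnc2cc(OCc3c(Cl)c(Cl)c(Cl)c(Cl)c3Cl)ccc2c1O`: 42700 nM
- compound 2 `O=C(O)c1cnc2cc(OCc3cccc4ccccc34)ccc2c1O`: 85100 nM
- compound 3 `O=C(O)c1cnc2cc(O)ccc2c1O`: 912000 nM

Compound 3, at 912000 nM, has the highest number of the three and so the weakest inhibition in this assay. Compound 2 and compound 1 both stand lower, each beyond the scatter.

The next compound is compound 4 `O=C(O)c1cnc2cc(F)ccc2c1O`, which keeps the core of compound 3 and carries fluoro in place of hydroxy on an aromatic carbon. Going by the values given here, no measured pair isolates a single change, and no measured compound carries fluoro, so the data give no direct guide to this step.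

Among the compounds with values here, compound 1 at 42700 nM and compound 2 at 85100 nM show only that much larger groups on the same carbon go with lower numbers than compound 3. Fluoro adds no such group, so no large gain is expected. The expected change is small and towards a lower number, a 1.8-fold lower number from compound 3 to compound 4 (0.26 log units; within the scatter), which stays within the scatter. For compound 4 the estimated value is 500000 nM, with an expected range from 150000 nM to 1500000 nM.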

Compound 4, half-maximal inhibitory concentration: 501000 nM
For compound 4 the middle estimate is 1.0-fold (0.00 log units) below the measured one; measured number inside the range.
By their numbers in this assay, from the lowest: compounds 1 and 2 (each within the scatter of the next); then compounds 4 and 3 (each within the scatter of the next).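

In this assay the step is a 1.8-fold lower number from compound 3 to compound 4 (0.26 log units; within the scatter), so at this aromatic carbon, para to a fused ring and meta to the other, hydroxy and fluoro cannot be told apart on this read-out. Going by these compounds alone, this adds something the earlier compounds could not show: the exchange takes away the hydrogen-bond donor and acceptor counted for hydroxy, as fluoro counts neither, and the number stays within the scatter, so in this pair the read-out does not depend on that donor and acceptor. No measured property of either group is available to account for this result.

The compounds shown leave open whether other single-atom or small groups on the same aromatic carbon, such as chloro, an amine or methoxy, would also stay within the scatter of compound 3 and compound 4. They also leave open whether this insensitivity to the exchange would hold if the carboxylic acid of the shared core gave way to an amide or an ester.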